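Trading trifluoromethyl for hydrogen in a cytotoxic compound

The source may hold more compounds than are shown below. What is called first, only, known or untested is meant among the compounds shown, and "the series" means these compounds.

In an ADME assay on L1210/0 cells (Mus musculus) for cytotoxicity, with a stated time of 48 h (on this read-out higher numbers stand for weaker inhibition and lower numbers for stronger inhibition), compound 1 (`CC1(C)[C@@H](Cn2cnc3c(O)nc(N)nc32)CC[C@@]1(C)CO`) gives > 200000 nM, which is a limit of the assay and not a measured number. Among the measured compounds shown here, compound 2 (`O=C1O/C(=C\Cn2cc(C(F)(F)F)c(=O)[nH]c2=O)C(OCc2ccccc2)=C1OCc1ccccc1`) gives 2000 nM, the only true number available, which makes it the one firm reference point here.

Compound 3 (`O=C1O/C(=C\Cn2ccc(=O)[nH]c2=O)C(OCc2ccccc2)=C1OCc1ccccc1`) has not yet been measured. It differs from compound 2 in a single place: hydrogen in place of trifluoromethyl on an aromatic carbon. Put simply, hydrogen takes the place of trifluoromethyl on an aromatic carbon of a six-membered aromatic ring with 2 nitrogen.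

For the measured compounds named here, no pair of measured compounds shows what this kind of swap does, so any forecast is uncertain and has to start from compound 2 at 2000 nM. Losing a group of this size is expected to weaken inhibition clearly, by more than the usual scatter between repeated measurements, which would mean a higher number in this assay. The estimated step of a 10-fold higher number from compound 2 to compound 3 (1.00 log units; beyond the scatter) points in that direction. For compound 3 the expected value is 20000 nM, with a likely range from 4000 nM to 100000 nM.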

Compound 3, half-maximal inhibitory concentration: 12900 nM
Compound 3: middle estimate off by 1.6-fold (0.19 log units), on the high side; measured number inside the range.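

Hydrogen in place of trifluoromethyl on this aromatic carbon gives the first step that can be read in this assay: a 6.5-fold higher number from compound 2 to compound 3 (0.81 log units; beyond the scatter). Among the compounds shown here, a higher number here means weaker inhibition, so the trifluoromethyl group of compound 2 clearly contributes to the cytotoxic effect, which the earlier compounds alone could not show. Even so, the group is not essential for activity: compound 3 still gives a true reading of 12900 nM. Compound 1 sits at a limit of the assay and not at a number: the limit of > 200000 nM in this assay, at which 1 of the 3 values shown sits.

This single pair shows only the two ends of one swap, so it leaves open how a methyl group, a chlorine atom or an amine on the same aromatic carbon would compare with trifluoromethyl and hydrogen. It also cannot tell which feature of trifluoromethyl accounts for the step, or whether the same swap would have a similar effect on a different core or in other cells.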